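Aryl urea series: cytotoxicity on BJ cells, compound 3

The source may report more compounds than this note shows. Statements on the series, on what has been measured and on what is new or still open speak of the compounds shown alone.

For the measured compounds named here, compound 2 `Cc1cc(NC(=O)Nc2cccc(OC(F)(F)F)c2)c2ccccc2n1` is the only member of the series with a number in an ADME assay on BJ cells (Homo sapiens) for cytotoxicity, with a stated time of 72 h; on this read-out lower numbers stand for an effect already at smaller amounts and higher numbers for an effect only at larger amounts of compound: compound 2 gives 25000 nM. Compound 1 `Cc1cc(NC(=O)Nc2cccc([N+](=O)[O-])c2)c2ccccc2n1` carries a nitro group in place of the trifluoromethoxy of compound 2, and in this assay compound 1 gives > 25000 nM, which is a limit of the assay and not a number. The step of a number no higher from compound 1 to compound 2 (the limit leaves the size open), trifluoromethoxy in place of nitro on an aromatic carbon, therefore has no readable size because of the limit of > 25000 nM in this assay, at which 1 of the 2 values shown sits.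

Compound 3 `Cc1cc(NC(=O)Nc2cccc(C(C)(C)C)c2)c2ccccc2n1` is not yet measured in this assay. Relative to compound 2 it differs by tert-butyl in place of trifluoromethoxy on an aromatic carbon. Going by the values given here, the only measured step, from compound 1 to compound 2, concerns the same aromatic carbon, but its size is open, so it gives no direction for the present change. With one number and one limit at the same level, no step beyond the scatter is expected. Compound 3 is therefore estimated at 25000 nM (range 12000 nM to 50000 nM) in this assay, which means an expected step of no change at the digits printed from compound 2 to compound 3 (within the scatter). A limit rather than a number is about as likely as not.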

Compound 3, half-maximal effective concentration in the BJ assay: > 25000 nM
Compound 3 ended at the assay's limit; the forecaster's own chance of this, stated with the estimate: 50%; the middle value lies on the limit itself.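

In the BJ assay compound 3, like compound 1, stands at a limit of the assay and not at a number. In the BJ assay the change gives a number no lower from compound 2 to compound 3 (the limit leaves the size open), and the steps to compound 3 in this read-out cannot be read because of that limit: the limit of > 25000 nM in the BJ assay, at which 2 of the 3 values shown sit.

The change does separate the compounds on another read-out: in a physicochemical assay for solubility, at pH 7.4 (on this read-out higher numbers stand for higher solubility and lower numbers for lower solubility), compound 2 gives 600 nM and compound 3 gives 34700 nM. This aromatic carbon is therefore a place where tert-butyl in place of trifluoromethoxy moves solubility by a readable amount, which the earlier compounds did not show: the measured solubility of compound 2, 600 nM, and of compound 3, 34700 nM, a 58-fold higher number (1.76 log units; beyond the scatter)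

Going by these compounds, what an amine or a carboxylic acid on this aromatic carbon would give in the physicochemical assay stays open, as does whether either group would give a number rather than a limit in the BJ assay. On these data alone, whether a longer chain in place of tert-butyl would keep the solubility of compound 3 also stays open.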